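This account rests on a few compounds, and the source may have more. Where it says the series, first, only, none or still open, it means among the compounds named here.

Working notes on the series. Of the compounds shown here, three have been measured so far. Compound 1 `Cc1cc(Nc2ncnc3cc(O)c(NC(=O)/C=C/[C@H]4CCCN4C)cc23)ccc1Oc1ccn2ccnc2c1` gives in a functional assay on NCI-N87 cells (Homo sapiens) for inhibition, read by CellTiter-Glo, with a stated time of 72 h (on this read-out higher numbers stand for weaker inhibition and lower numbers for stronger inhibition), a value of 4.55 nM. Compound 2 `Cc1cc(Nc2ncnc3cc(O)c(NC(=O)/C=C/[C@H]4CCCN4C)cc23)ccc1Oc1ccc2nccn2c1` gives in this assay a value of 4.08 nM, the lowest number of the three, though the gaps to compound 1 and to compound 3 both sit within the scatter. Compound 3 `C=C(F)C(=O)Nc1cc2c(Nc3ccc(Oc4cc5nncn5cn4)c(C)c3)ncnc2cc1OCC`, built on a different core with a different amide, gives in this assay a value of 6.56 nM.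

Going by the values given here, the single step measured between neighbours that differ in one place is a 1.1-fold lower number from compound 1 to compound 2 (0.05 log units; within the scatter); it exchanges one two-ring aromatic group on the ring oxygen for another and leaves the number essentially unchanged.

Compound 4 `Cc1cc(Nc2ncnc3cc(O)c(NC(=O)/C=C/[C@H]4CCCN4C)cc23)ccc1Oc1ccn2ncnc2c1` is not yet measured. It differs from compound 2 only at the same position: a group of 9 heavy atoms (6 carbon, 3 nitrogen; one five-membered aromatic ring with 3 hetero atoms, one six-membered aromatic ring with 1 hetero atom) in place of a group of 9 heavy atoms (7 carbon, 2 nitrogen; one five-membered aromatic ring with 2 hetero atoms, one six-membered aromatic ring with 1 hetero atom), on an oxygen on an aromatic ring. The step from compound 1 to compound 2 is the only one that bears on it, and it was within the scatter, so no step beyond the scatter is expected in this assay in either direction. The estimated step is a 1.2-fold higher number from compound 2 to compound 4 (0.09 log units; within the scatter). Compound 4 is expected to give about 5 nM, with a range from 2.5 nM to 10 nM.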

Compound 4, half-maximal inhibitory concentration: 2.65 nM
The estimate for compound 4 lay 1.9-fold (0.28 log units) above the measured number, within the range that was stated.
By their numbers in this assay, from the lowest: compounds 4, 2, 1 and 3 (each within the scatter of the next, the first and the last beyond it).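

On the oxygen on an aromatic ring, the group with 6 carbon and 3 nitrogen gives a 1.5-fold lower number from compound 2 to compound 4 (0.19 log units; within the scatter) and a 1.7-fold lower number from compound 1 to compound 4 (0.23 log units; within the scatter) in this assay. The earlier step only exchanged one group of 7 carbon and 2 nitrogen for another, whereas these two steps change the atoms of the five-membered aromatic ring itself and still stay within the scatter, so all three groups at this position in compounds 1, 2 and 4 read alike. No measurement is at hand that could explain this result.

The compounds shown leave open whether the position keeps these numbers with a group of another kind on the oxygen, such as a plain phenyl ring, a morpholine or a longer alkyl chain. They also leave open whether the same exchange of groups reads alike on the core of compound 3 with its different amide.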